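Phenyl in place of methyl on a shared core

The source may report more compounds than this note shows. Statements on the series, on what has been measured and on what is new or still open speak of the compounds shown alone.

Three measured compounds share one core and differ only in the group that hangs from one aromatic carbon. Compound 1 `CN/C=N/c1cc(-c2ccccc2)nn1-c1ccccc1` carries the smallest of these groups. In a functional assay on NPC-TW01 cells (Homo sapiens) for inhibition, read by MTT assay, with a stated time of 72 h (on this read-out lower numbers stand for stronger inhibition of growth and higher numbers for weaker inhibition of growth), compound 1 gives > 50000 nM, which is a limit of the assay and not a number. Compound 2 `CC/C(=N\c1cc(-c2ccccc2)nn1-c1ccccc1)NC` and compound 3 `C/C(=N\c1cc(-c2ccccc2)nn1-c1ccccc1)N(C)C` carry larger groups at the same carbon. In this assay compound 2 gives > 50000 nM, again a limit. In this assay compound 3 gives > 50000 nM, also a limit. On these data alone, because of the limit of > 50000 nM in this assay, at which 3 of the 3 values shown sit, the steps a step that the two limits leave unreadable from compound 1 to compound 2, a step that the two limits leave unreadable from compound 1 to compound 3 and a step that the two limits leave unreadable from compound 2 to compound 3 cannot be read in size, and how far any of the three lies past that boundary is unknown.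

Compound 4 `CN(C)/C(=N/c1cc(-c2ccccc2)nn1-c1ccccc1)c1ccccc1` has not yet been measured. It differs from compound 3 by phenyl in place of methyl on a carbon with a double bond to nitrogen. Within the data shown here, none of the measured steps touches this position, and all three were unreadable, so they give neither a direction nor a size to expect. Among the measured compounds shown here, the only anchor is that compound 3 itself stands at a limit. Compound 4 is therefore expected to give about 50000 nM in this assay, somewhere between 15000 nM and 200000 nM, and most probably as a limit once more. The expected step of a number no higher from compound 3 to compound 4 (the limit leaves the size open) is accordingly estimated to be no larger than the scatter.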

Compound 4, concentration for 50% growth inhibition: 20800 nM
For compound 4 the middle estimate is 2.4-fold (0.38 log units) above the measured one; low and high end bracket the measured number.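

In this assay, phenyl in place of methyl on a carbon with a double bond to nitrogen gives an at least 2.4-fold lower number from compound 3 to compound 4 (0.38 log units; beyond the scatter), and a lower number here means stronger inhibition of growth. Among these compounds, this is the only step in the set whose direction can be read, and it shows that growth inhibition does respond to the group at this carbon, something the three earlier compounds could not show. The full size of the step stays open, because compound 3 is one of the compounds whose result is a limit of the assay and not a number: the limit of > 50000 nM in this assay, at which 3 of the 4 values shown sit.

A single pair cannot tell whether the change depends on the aromatic ring of phenyl or would also follow from another larger group, such as cyclohexyl or a longer chain. The compounds shown also leave open how a phenyl carrying a chlorine or a methoxy group would behave at this carbon, and whether phenyl would give a readable value alongside a methylamine in place of the dimethylamine of compound 4.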